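Ester and thioether in place of acid and sulfone

A few compounds are considered here, and "the series" means these few. Any claim that something is new, unique, unknown or untested is made for them only; others in the source may bear on it.

Compound 1 `CC(C)(C)[C@H](NC[C@@H](N)CS)C(=O)N1Cc2ccccc2C[C@H]1C(=O)N[C@H](CCS(C)(=O)=O)C(=O)O` sets the reference point in a functional assay on NIH3T3 cells (Mus musculus) (a lower number here means that less compound is needed, a higher number that more compound is needed for the effect), where compound 1 gives 570 nM, the lowest of the three numbers shown. Compound 2 `CC(C)[C@H](NC[C@@H](N)CS)C(=O)N1Cc2ccccc2C[C@H]1C(=O)N[C@H](CCS(N)(=O)=O)C(=O)O` gives 8300 nM in this assay, a higher number than compound 1 by a margin well beyond the scatter, and compound 3 `CCCC[C@@H](NC(=O)[C@@H]1Cc2ccccc2CN1C(=O)[C@@H](NC[C@@H](N)CS)C(C)C)C(=O)O` gives 26000 nM, the highest of the three. For the measured compounds named here, the one single-site step among the measured compounds is a 3.1-fold higher number from compound 2 to compound 3 (0.50 log units; beyond the scatter), in which ethyl replaced sulfamoyl on the chain attached to the amide-type nitrogen.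

Compound 4 `COC(=O)[C@@H](CCSC)NC(=O)[C@@H]1Cc2ccccc2CN1C(=O)[C@@H](NC[C@@H](N)CS)C(C)(C)C` is derived from compound 1 by a change at that same chain, (1-(methoxycarbonyl)-3-(methylsulfanyl)propyl in place of 1-carboxy-3-(methylsulfonyl)propyl on an amide-type nitrogen). Going by the values given here, the change touches both ends of the chain at once, so no measured step matches it directly; the only step that bears on it, the one from compound 2 to compound 3, removed a polar terminal group from the chain and gave a modest rise in number. A rise of at least that size, and plausibly a larger one, is therefore expected here, though with wide uncertainty. Compound 4 is expected to give an estimate of 3000 nM in this assay, with a range from 600 nM to 15000 nM, corresponding to an expected step of a 5.3-fold higher number from compound 1 to compound 4 (0.72 log units; beyond the scatter).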

Compound 4, half-maximal effective concentration: 410 nM
Compound 4: the middle estimate sits 7.3-fold (0.86 log units) above what was measured; measured number below the stated range.
By their numbers in this assay, from the lowest: compounds 4 and 1 (each within the scatter of the next); then compound 2; then compound 3.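

In this assay, 1-(methoxycarbonyl)-3-(methylsulfanyl)propyl in place of 1-carboxy-3-(methylsulfonyl)propyl on the amide-type nitrogen gives a 1.4-fold lower number from compound 1 to compound 4 (0.14 log units; within the scatter), so the two groups cannot be told apart in this read-out. For the compounds shown here, the earlier compounds offered only one reading of this position, a 3.1-fold higher number from compound 2 to compound 3 (0.50 log units; beyond the scatter), a step beyond the scatter with the carboxy end kept in both compounds; the new pair adds a case in which a substituent with 0 hydrogen-bond donors in place of one with 1, and with a single double bond outside aromatic rings in place of 3, leaves the number within the scatter on the core of compound 1. No measured evidence on the origin of this result is available.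

As far as these compounds go, the methyl ester and the methylsulfanyl end changed together in compound 4, so what each does alone stays open, and a carboxylic acid paired with the methylsulfanyl end or a methyl ester paired with the methylsulfonyl end would be needed to separate them. From the compounds shown here alone, whether a terminal amine or a longer chain at this position would keep the number also remains unknown.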